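Flipping the double bond of compound 1

The source may hold more compounds than are shown below. What is called first, only, known or untested is meant among the compounds shown, and "the series" means these compounds.

Going by the values given here, compound 1 (`COc1ccc(/C=C/c2cc(OC)c(OC(C)=O)c(OC)c2)cc1`) is the only compound with a true number so far: in a functional assay on MCF7 cells (Homo sapiens) for cytotoxicity (a lower number here means that less compound is needed, a higher number that more compound is needed for the effect), compound 1 gives 19.4 uM. Among the compounds with values here, its one measured neighbour, compound 2 (`COc1ccc(/C=C/c2cc(OC)c(OCc3ccccc3)c(OC)c2)cc1`), carries benzyl in place of acetyl on an oxygen on an aromatic ring. Compound 2 gives > 25 uM, which is a limit of the assay and not a number. The comparison shows an at least 1.2-fold higher number from compound 1 to compound 2 (0.11 log units; that floor lies within the scatter). That step concerns a different part of the molecule, and the limit of > 25 uM in this assay, at which 1 of the 2 values shown sits, marks how little room the assay leaves at the top.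

Compound 3 (`COc1ccc(/C=C\c2cc(OC)c(OC(C)=O)c(OC)c2)cc1`) keeps the acetyl and alters something else: the two compounds have the same atoms and bonds and differ only in configuration as drawn: 1 of 1 stereo elements differ; a double bond is drawn E in compound 1 and Z in compound 3. Within the data shown here, no measured step touches this double bond, so the data give no direct guide to the size of the change in this assay, and either direction remains possible. Since compound 1 stands at 19.4 uM there is more room for a lower number than for a higher one, so a moderate fall is expected. The expected step is a 2.8-fold lower number from compound 1 to compound 3 (0.44 log units; beyond the scatter), and it is uncertain. For compound 3 the estimate is 7 uM, with an expected range from 0.8 uM to 25 uM.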

Compound 3, concentration for half-maximal effect: > 25 uM
Compound 3: only a limit was reported; the forecaster's own chance of this, stated with the estimate: 15%; middle value at least 3.5-fold (0.55 log units) from the limit.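

In this assay compound 3 gives > 25 uM, which is a limit of the assay and not a number. The step is an at least 1.2-fold higher number from compound 1 to compound 3 (0.11 log units; that floor lies within the scatter), so this first look at the double bond gives no sign of a lower number, while the true size of the change stays hidden at the top of the assay: the limit of > 25 uM in this assay, at which 2 of the 3 values shown sit. Whatever separates the two compounds can be traced to the double bond alone, because no atom or bond changes anywhere else: the fact that compounds 1 and 3 differ only in the configuration as drawn

The compounds shown leave open how far the Z form really lies from the E form, and whether flipping the double bond would have the same outcome with the benzyl of compound 2 in place of the acetyl. They also leave open whether a free hydroxyl or an amine at the place of the acetyl, in either form of the double bond, would bring the number down to a range where this assay can give true values to compare.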